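Nitro in place of hydrogen, starting from a limit

A few compounds are considered here, and "the series" means these few. Any claim that something is new, unique, unknown or untested is made for them only; others in the source may bear on it.

Measured values in a functional assay on KB cells (Homo sapiens) for inhibition (on this read-out higher numbers stand for weaker inhibition and lower numbers for stronger inhibition), follow.
- Compound 1 `Clc1cc2nc(Br)n(Cc3ccccc3)c2cc1Cl` gives > 100000 nM as a limit
- Compound 2 `Clc1cccc(Cn2c(Br)nc3cc(Cl)c(Cl)cc32)c1` gives > 100000 nM as a limit

Compound 1 stands at > 100000 nM in this assay and this is a limit, not a number. Compound 3 `O=[N+]([O-])c1ccc(Cn2c(Br)nc3cc(Cl)c(Cl)cc32)cc1` keeps the core of compound 1 and carries nitro in place of hydrogen on an aromatic carbon, para to a large group (nitro in place of hydrogen on an aromatic carbon). Among the compounds with values here, the one measured step also replaces a hydrogen on an aromatic carbon, and it is a step that the two limits leave unreadable from compound 1 to compound 2 with no size to carry over. All the data offer is the limit of > 100000 nM in this assay, at which 2 of the 2 values shown sit, and nothing more. With no readable step to build on, no change beyond the scatter is expected in this assay and another limit is the likeliest report. The expected step is a number no higher from compound 1 to compound 3 (the limit leaves the size open) in size. For compound 3 the estimated value is 100000 nM with an expected range from 30000 nM to 300000 nM around it.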

Compound 3, half-maximal inhibitory concentration: 40000 nM
The estimate for compound 3 lay 2.5-fold (0.40 log units) above the measured number, and the stated range covers the measured number.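

In this assay nitro in place of hydrogen on the six-membered aromatic ring of carbon only, para to a large group, gives an at least 2.5-fold lower number from compound 1 to compound 3 (0.39 log units; beyond the scatter) and so moves the read-out towards stronger inhibition. The earlier step, with chloro in place of hydrogen, cannot be read, which leaves this as the only change shown so far that has a readable direction. Going by these compounds, how large the gain really is stays open, because the starting point is only a limit and not a number: the limit of > 100000 nM in this assay, at which 2 of the 3 values shown sit.

On these data alone, whether this gain is specific to nitro remains unknown, since an amine or a carboxylic acid at the same place could give a smaller, similar or larger change. It is also unknown whether nitro elsewhere on this ring would lower the number as well.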